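A few compounds are considered here, and "the series" means these few. Any claim that something is new, unique, unknown or untested is made for them only; others in the source may bear on it.

In a functional assay on the whole organism (Hindlimb, strain albino) with Mus musculus as the target, in the maximal electroshock model, with a stated time of 0.5 h (on this read-out lower numbers stand for an effect already at smaller amounts and higher numbers for an effect only at larger amounts of compound), compound 1 (`COc1ccc(C2CC(Nc3nc4ccc(C)cc4s3)=NN2C(C)=O)cc1`) gives 37.3 umol/kg and compound 2 (`COc1ccc(C2CC(Nc3nc4ccc(C)cc4s3)=NN2C(C)=O)cc1O`) gives 73.9 umol/kg. Compound 3 (`CC(=O)N1N=C(Nc2nc3ccccc3s2)CC1c1ccc(Cl)cc1`) stands highest of the three at 209 umol/kg, beyond the scatter from both of the others.

The next structure, compound 4 (`CC(=O)N1N=C(Nc2nc3ccc(C)cc3s2)CC1c1ccc(Cl)cc1`), differs from compound 3 by methyl in place of hydrogen on an aromatic carbon. Within the data shown here, no measured step shows this change directly. Among the measured compounds shown here, the only step available is a 2.0-fold higher number from compound 1 to compound 2 (0.30 log units; within the scatter), which is hydroxy in place of hydrogen on an aromatic carbon, so it offers no size for the methyl change.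

The indirect evidence is weak. Compound 1 at 37.3 umol/kg and compound 2 at 73.9 umol/kg both carry the methyl that compound 4 gains, and compound 3 at 209 umol/kg has the highest number of the three. However, these two compounds also differ from compound 3 elsewhere in the structure, so the gap cannot be assigned to the methyl alone.

A modest shift toward a lower number in this assay is therefore expected, though a change within the scatter remains possible. The expected change is a 2.1-fold lower number from compound 3 to compound 4 (0.32 log units; beyond the scatter). For compound 4 the estimated value is 100 umol/kg, with an expected range from 30 umol/kg to 300 umol/kg.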

Compound 4, dose for half-maximal effect: 25.5 umol/kg
The estimate for compound 4 lay 3.9-fold (0.59 log units) above the measured number; the measured number lies below the stated range.
By their numbers in this assay, from the lowest: compounds 4, 1 and 2 (each within the scatter of the next, the first and the last beyond it); then compound 3.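

In this assay, the change of hydrogen to methyl on the aromatic carbon of the fused two-ring system now has a direct measure, an 8.2-fold lower number from compound 3 to compound 4 (0.91 log units; beyond the scatter), and it shows that this position is sensitive to a single added carbon when the 4-chlorophenyl group stays in place. With the methyl present, chloro in place of methoxy on an aromatic carbon gives a 1.5-fold lower number from compound 1 to compound 4 (0.17 log units; within the scatter), which leaves those two compounds unseparated, while 4-chlorophenyl in place of 3-hydroxy-4-methoxyphenyl gives a 2.9-fold lower number from compound 2 to compound 4 (0.46 log units; beyond the scatter), a smaller step than the one the methyl produces. The compounds shown come with no measurement that would explain why the methyl has a step of this size.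

As far as these compounds go, the hydrogen form appears here only with the 4-chlorophenyl group, so it remains open whether the methyl step would be of like size alongside the methoxyphenyl group of compound 1 or the 3-hydroxy-4-methoxyphenyl group of compound 2. From the compounds shown here alone, it is also open whether an ethyl group, a methoxy group or an amine on this same carbon would match the methyl, and whether the methyl would give the same step on another carbon of that ring.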